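The source may report more compounds than this note shows. Statements on the series, on what has been measured and on what is new or still open speak of the compounds shown alone.

Measured so far:
compound 1 `O=C1Nc2ccccc2/C1=N/NC(=S)N1CCN(c2ccccc2)CC1` gives 11100 nM
compound 2 `O=C1Nc2cccc(Cl)c2/C1=N/NC(=S)N1CCN(c2ccccc2)CC1` gives 42100 nM
compound 3 `O=C1Nc2ccccc2/C1=N/NC(=S)Nc1ccccc1` reaches only a limit of the assay, > 100000 nM

All three were read in a functional assay on HCT-116 cells (Homo sapiens) for inhibition, read by MTT assay, with a stated time of 72 h; a lower number here means a stronger inhibitor, a higher number a weaker inhibitor. Compound 1 and compound 2 share a core and differ by one change, (chloro in place of hydrogen on an aromatic carbon); the result was a 3.8-fold higher number from compound 1 to compound 2 (0.58 log units; beyond the scatter). Compound 3 carries a different core; the difference between the two cores is not broken down here. For compound 3 the assay gives no number, only (the limit of > 100000 nM in this assay, at which 1 of the 3 values shown sits).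

Compound 4 `O=C1Nc2ccc(Cl)cc2/C1=N/NC(=S)Nc1ccccc1` has not yet been measured in this assay. It differs from compound 3 by chloro in place of hydrogen on an aromatic carbon. This is the same kind of change as between compound 1 and compound 2, not the same: there the chloro sits ortho to a fused ring and meta to a fused ring, here meta to a fused ring and para to a fused ring. The measured step went toward weaker inhibition, and compound 3 already sits at the limit given by the limit of > 100000 nM in this assay, at which 1 of the 3 values shown sits; a further weakening would therefore most probably leave compound 4 beyond the measurable range as well. Compound 4 is expected to give about 150000 nM, within 60000 nM to 400000 nM, and most likely only a limit. The expected step is a step that the limit leaves unreadable from compound 3 to compound 4, judged against a 3.8-fold higher number from compound 1 to compound 2 (0.58 log units; beyond the scatter).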

Compound 4, half-maximal inhibitory concentration: 30800 nM
Estimate against measurement, compound 4: 4.9-fold (0.69 log units) above; the measured number lies below the stated range.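

In this assay, chloro in place of hydrogen on an aromatic carbon gives an at least 3.2-fold lower number from compound 3 to compound 4 (0.51 log units; beyond the scatter), so within this series the change does not keep its direction from one core to the other: the same change on two cores in this assay, a 3.8-fold higher number (0.58 log units; beyond the scatter) from compound 1 to compound 2 and an at least 3.2-fold lower number (0.51 log units; beyond the scatter) from compound 3 to compound 4, at least 12-fold (1.09 log units) apart, beyond the scatter of two such steps. For compound 3, > 100000 nM is a limit of the assay and not a number, so the full size of the new step stays unread, though its direction is clear. The chloro also sits in a different place on the aromatic ring in compound 2 and compound 4, so the two steps differ in both core and position, and these compounds do not show which of the two accounts for the reversal.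

Open, from the compounds shown here alone, is what chloro would do on the core of compound 1 in the place it holds in compound 4, and on the core of compound 3 in the place it holds in compound 2. Also open, going by these compounds, is whether bromo, methoxy or an amine in either place would follow chloro on each core.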